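The compounds below may be only part of what the source reports. "The series", "measured", "known", "first", "only" and "open" are said of these compounds alone.

Measured so far: compound 1 `CCCCC(OC)c1cccc(NC(=O)NC(=O)CC)c1` and compound 2 `CCCCC(OC)c1cccc(NC(=O)CCl)c1`.

In a functional assay on HT-29 cells (Homo sapiens) for antiproliferative activity, with a stated time of 48 h (on this read-out higher numbers stand for weaker inhibition and lower numbers for stronger inhibition), compound 1 gives only a limit, > 100000 nM. In this assay, among the compounds with values here, compound 2 gives 13000 nM, the only number in the set. Compound 3 `CCCCC(OC)c1cccc(NC(=O)CCCl)c1` is not yet measured; relative to compound 2 it carries chloromethyl in place of chloro on a saturated chain carbon bound to a carbonyl carbon. Within the data shown here, the one measured step, an at least 7.6-fold lower number from compound 1 to compound 2 (0.88 log units; beyond the scatter), concerns the group on the carbonyl carbon and rests on the limit (the limit of > 100000 nM in this assay, at which 1 of the 2 values shown sits), so it offers no direct guide for moving the chloro outward along the chain. Weaker inhibition is expected for compound 3, a step of a 3.1-fold higher number from compound 2 to compound 3 (0.49 log units; beyond the scatter). Compound 3 is estimated at 40000 nM, between 12000 nM and 130000 nM.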

Compound 3, half-maximal inhibitory concentration: > 100000 nM
Compound 3 ended at the assay's limit (the forecaster's own chance of this, stated with the estimate: 40%); middle value at least 2.5-fold (0.39 log units) from the limit.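

In this assay the change from chloromethyl to 2-chloroethyl gives an at least 7.6-fold higher number from compound 2 to compound 3 (0.88 log units; beyond the scatter) and shows that this position responds to a small change within the chloroalkyl group, not only to replacement of the whole group. Among the compounds shown, only the chloromethyl compound 2 gives a number rather than a limit. The remaining step, between compound 1 and compound 3, cannot be read: the limit of > 100000 nM in this assay, at which 2 of the 3 values shown sit.

Still open, on these data alone, is whether bromomethyl or an aminomethyl group on the carbonyl carbon would keep the activity of compound 2. As far as these compounds go, the true size of the loss with 2-chloroethyl also stays open.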